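The compounds below may be only part of what the source reports. "The series", "measured", "known", "first", "only" and "open" are said of these compounds alone.

In a functional assay on HUVEC cells (Homo sapiens) for inhibition, with a stated time of 4 days (on this read-out higher numbers stand for weaker inhibition and lower numbers for stronger inhibition), compound 1 (`COc1ccc(C#N)cc1COc1ccc(Cl)c(C)c1`) gives 1500 nM, and compound 3 (`COc1ccc(C(=O)N(C)C)cc1/C=C/c1ccc(Cl)cc1`) gives 2500 nM, which lies within the scatter of compound 1. Compound 2 (`CCOc1ccc(C(N)=O)cc1/C=C/c1ccc(Cl)cc1`) differs from compound 3 in more than one place. Compound 2 gives 190 nM, a number beyond the scatter below that of compound 3. Compound 4 (`COc1ccc(C(=O)NC(CO)CO)cc1/C=C/c1ccc(Cl)cc1`) has (2-hydroxy-1-(hydroxymethyl)ethyl)amino in place of dimethylamino on a carbonyl carbon. Among the measured compounds shown here, no measured pair isolates this change, so the expectation leans only on compound 2 at 190 nM, which also lacks dimethylamino on that carbonyl carbon. A lower number, beyond the scatter, is expected, estimated as a 4.2-fold lower number from compound 3 to compound 4 (0.62 log units; beyond the scatter). Compound 4 is expected at 600 nM, within an estimated range of 180 nM to 2200 nM.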

Compound 4, half-maximal inhibitory concentration: 1500 nM
Beside the measured number, compound 4's estimate is 2.5-fold (0.40 log units) below it, and the stated range covers the measured number.
By their numbers in this assay, from the lowest: compound 2; then compounds 1, 4 and 3 (each within the scatter of the next).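

Among the compounds shown here, this is the first pair that differs in one place, and it gives a 1.7-fold lower number from compound 3 to compound 4 (0.22 log units; within the scatter) in this assay. On this carbonyl carbon, (2-hydroxy-1-(hydroxymethyl)ethyl)amino and dimethylamino therefore cannot be told apart, although the entering group is larger and carries hydroxyl groups. Nothing available explains this result. Still open, from the compounds shown here alone, is whether a plain amino group or a methylamino group on the same carbonyl carbon, with the rest of compound 3 unchanged, would move the number beyond the scatter. Also open, going by these compounds, is whether a single hydroxyethylamino chain would behave like the group in compound 4.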